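This account rests on a few compounds, and the source may have more. Where it says the series, first, only, none or still open, it means among the compounds named here.

Measured so far in a functional assay on UACC-257 cells (Homo sapiens) for cytotoxicity, read by sulforhodamine B assay, with a stated time of 48 h; a higher number here means a weaker inhibitor of growth, a lower number a stronger inhibitor of growth:
compound 1 `ClCc1ccc(Cn2cnc3c(Cl)ncnc32)cc1`: 7410 nM
compound 2 `Nc1nc(Cl)c2ncn(Cc3ccc(CCl)cc3)c2n1`: 12600 nM

Among the compounds with values here, compound 2 stands highest of the two numbers in this assay, but the only measured step, a 1.7-fold higher number from compound 1 to compound 2 (0.23 log units; within the scatter), lies within the scatter, so the two compounds cannot be ordered.

Compound 3 `ClCc1ccc(Cn2cnc3c(Cl)nc(Cl)nc32)cc1` differs from compound 2 by chloro in place of amino on an aromatic carbon. Within the data shown here, the one step that bears on this position is a 1.7-fold higher number from compound 1 to compound 2 (0.23 log units; within the scatter), which was within the scatter; a change at the same carbon is therefore expected to move this assay by no more than the scatter, in no settled direction. Compound 3 is estimated at 8500 nM, range 3500 nM to 20000 nM. The expected step is a 1.5-fold lower number from compound 2 to compound 3 (0.17 log units; within the scatter).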

Compound 3, concentration for 50% growth inhibition: 16200 nM
The estimate for compound 3 lay 1.9-fold (0.28 log units) below the measured number; low and high end bracket the measured number.
By their numbers in this assay, from the lowest: compounds 1, 2 and 3 (each within the scatter of the next, the first and the last beyond it).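

At the carbon between two ring nitrogen atoms, chloro and amino are not told apart in this assay (a 1.3-fold higher number from compound 2 to compound 3 (0.11 log units; within the scatter)). Chloro in place of hydrogen at that carbon gives the first step in the series beyond the scatter, a modest one towards weaker inhibition of growth (a 2.2-fold higher number from compound 1 to compound 3 (0.34 log units; beyond the scatter)). No measurement available here accounts for this shift.
As far as these compounds go, whether a methoxy group or a methyl group at this carbon would stay within the same narrow range remains open. So does whether any group there could give stronger inhibition than hydrogen.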